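Thiophene for chlorophenyl on a weakly active thiosemicarbazone

The source may report more compounds than this note shows. Statements on the series, on what has been measured and on what is new or still open speak of the compounds shown alone.

The series shares a core carrying a thiosemicarbazone arm; compound 1 `CC1=CC[C@H](C(C)(C)NC(=S)N/N=C/c2cccc(Cl)c2)CC1` bears a 3-chlorophenyl on the carbon double-bonded to nitrogen. In a functional assay on MCF7 cells (Homo sapiens) for inhibition, read by sulforhodamine B assay, with a stated time of 48 h (on this read-out higher numbers stand for weaker inhibition of growth and lower numbers for stronger inhibition of growth), compound 1 gives 61000 nM. Compound 2 `CC1=CC[C@H](C(C)(C)NC(=S)N/N=C/c2ccc(Cl)cc2)CC1` carries a 4-chlorophenyl at the same carbon. In this assay compound 2 reaches only the limit of the assay, > 100000 nM, so no number is known for it. The step of an at least 1.6-fold higher number from compound 1 to compound 2 (0.21 log units; that floor lies within the scatter) rests on (the limit of > 100000 nM in this assay, at which 1 of the 2 values shown sits), and compound 2 therefore stands at the weak end of what the assay can report. Compound 3 `CC1=CC[C@H](C(C)(C)NC(=S)N/N=C/c2cccs2)CC1` is the next variation: thiophen-2-yl in place of 4-chlorophenyl on a carbon with a double bond to nitrogen. Among the measured compounds shown here, no measured step covers an exchange of this kind; the single measured step concerns only the position of the chlorine. With compound 2 already at the limit, compound 3 is expected to remain weak, and the step of an at least 1.1-fold lower number from compound 2 to compound 3 (0.04 log units; that floor lies within the scatter) is estimated to stay within the scatter. Compound 3 is accordingly expected to give about 90000 nM, within 30000 nM to 300000 nM.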

Compound 3, concentration for total growth inhibition: 11500 nM
For compound 3 the middle estimate is 7.8-fold (0.89 log units) above the measured one, and the stated range ends above it.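

Among the compounds shown here, at the carbon with a double bond to nitrogen, the earlier compounds differed only in where the chlorine sits, whereas here the aromatic ring itself changes, and in this assay this gives a shift beyond the scatter: a 5.3-fold lower number from compound 1 to compound 3 (0.72 log units; beyond the scatter). Against the 4-chlorophenyl the change reads an at least 8.6-fold lower number from compound 2 to compound 3 (0.93 log units; beyond the scatter), and that size is only a floor, resting on a limit of the assay for compound 2: the limit of > 100000 nM in this assay, at which 1 of the 3 values shown sits. Growth inhibition at this position therefore responds to the kind of ring, although compound 3 is the only thiophene shown.

Going by these compounds, what a plain phenyl, a furan-2-yl or a pyridin-2-yl would give at this carbon remains open. So does whether the gain follows the sulfur atom, the smaller ring or the loss of chlorine, and whether a chlorine on the thiophene would keep it.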